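The source may hold more compounds than are shown below. What is called first, only, known or untested is meant among the compounds shown, and "the series" means these compounds.

Measured in an ADME assay on BJ cells (Homo sapiens) for cytotoxicity, with a stated time of 72 h (on this read-out lower numbers stand for an effect already at smaller amounts and higher numbers for an effect only at larger amounts of compound), as follows:
Compound 1 `COc1ccc(-c2nc3c(c(C)nn3-c3ccccc3)c(-c3ccccc3O)c2C#N)cc1`: > 23000 nM
Compound 2 `CCc1ccc(-c2nc3c(c(C)nn3-c3ccccc3)c(-c3ccccc3C(=O)O)c2C#N)cc1`: > 20000 nM

Compound 2 gives only a limit (> 20000 nM) and no number. Compound 1 likewise gives only a limit (> 23000 nM). Both values shown are therefore limits, and the two compounds cannot be ranked against each other.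

Next in line is compound 3 `C#Cc1ccccc1-c1c(C#N)c(-c2ccc(CC)cc2)nc2c1c(C)nn2-c1ccccc1`, not yet measured. Compared with compound 2 the change is ethynyl in place of carboxy on an aromatic carbon, ortho to a large group, or 2-carboxyphenyl to 2-ethynylphenyl.

Among the measured compounds shown here, no measured step covers this change, so the expectation rests on little. For the measured compounds named here, the only anchor is compound 2 with its limit (> 20000 nM). A small step is expected in this assay, toward lower numbers if there is one at all, and it may well stay within the usual scatter. The estimated step is an at least 1.1-fold lower number from compound 2 to compound 3 (0.04 log units; that floor lies within the scatter) on this basis. Compound 3 is estimated at 18000 nM with an expected range (6000 nM to 40000 nM), and a reading that is again only a limit is quite likely.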

Compound 3, half-maximal effective concentration: > 20000 nM
Compound 3: only a limit was reported (the forecaster's own chance of this, stated with the estimate: 70%); middle value at least 1.1-fold (0.04 log units) from the limit.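

In this assay compound 3 gives > 20000 nM, which is a limit and not a number. Compound 2 also gives only a limit, > 20000 nM, so no step can be read between compound 2 and compound 3. The compounds shown leave open whether 2-carboxyphenyl to 2-ethynylphenyl changes this read-out at all, and at what amount any of them would show an effect.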